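Thiophene swap at the aryl position: working notes

The source may hold more compounds than are shown below. What is called first, only, known or untested is meant among the compounds shown, and "the series" means these compounds.

- compound 1 `COc1cc(-c2cccc3nc(-c4cccc(Br)c4)oc23)cc(OC)c1OC`: 2100 nM
- compound 2 `COc1cc(-c2cccc3nc(-c4ccc(C)cc4)oc23)cc(OC)c1OC`: 680 nM
- compound 3 `COc1cc(-c2cccc3nc(-c4ccc(N)cc4)oc23)cc(OC)c1OC`: 720 nM

In a functional assay on A549 cells (Homo sapiens) for antiproliferative activity, read by MTT assay, with a stated time of 48 h (a lower number here means a stronger inhibitor, a higher number a weaker inhibitor), compound 3 sits level with compound 2: a 1.1-fold higher number from compound 2 to compound 3 (0.02 log units; within the scatter). It lies clear of compound 1: a 2.9-fold lower number from compound 1 to compound 3 (0.46 log units; beyond the scatter). Compound 4 `COc1cc(-c2cccc3nc(-c4cccs4)oc23)cc(OC)c1OC` has thiophen-2-yl in place of 4-aminophenyl on an aromatic carbon. Among the measured compounds shown here, no measured compound carries a five-membered ring at this place, so only the phenyl changes bear on it. These were modest, with a 3.1-fold lower number from compound 1 to compound 2 (0.49 log units; beyond the scatter) alongside a 2.9-fold lower number from compound 1 to compound 3 (0.46 log units; beyond the scatter). A step of about that size at most is expected, in either direction, and probably none beyond the scatter in this assay. The expected step is a 1.3-fold higher number from compound 3 to compound 4 (0.10 log units; within the scatter). Compound 4 is estimated at 900 nM, with an expected range of 350 nM to 2400 nM.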

Compound 4, half-maximal inhibitory concentration: 12500 nM
Beside the measured number, compound 4's estimate is 14-fold (1.14 log units) below it; the measured number lies above the stated range.
By their numbers in this assay, from the lowest: compounds 2 and 3 (each within the scatter of the next); then compound 1; then compound 4.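

In this assay, among the compounds shown here, the earlier phenyl changes stayed modest, but thiophen-2-yl gives a 17-fold higher number from compound 3 to compound 4 (1.24 log units; beyond the scatter) and an 18-fold higher number from compound 2 to compound 4 (1.26 log units; beyond the scatter) as the first large steps at this place. Even 3-bromophenyl holds up better, with a 6.0-fold higher number from compound 1 to compound 4 (0.77 log units; beyond the scatter) on the same swap, so the three phenyl groups all fare better here than thiophen-2-yl. Nothing available accounts for this loss. As far as these compounds go, whether furan-2-yl, thiophen-3-yl or unsubstituted phenyl would stay with compound 4 or return towards compound 2 and compound 3 remains open.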